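The source may report more compounds than this note shows. Statements on the series, on what has been measured and on what is new or still open speak of the compounds shown alone.

Compound 1 `COc1ccc(-c2c(C)sc3c(N4CC[C@@H](NC(C)=O)C4)nc(C)nc23)cc1OC`: > 95%
Compound 2 `COc1cc(-c2c(C)nc3c(N4CC[C@@H](NC(C)=O)C4)cc(C)nn23)cc(OC)c1OC`: > 95%
Compound 3 `CC(=O)N[C@@H]1CCN(c2cc(C)nn3c(-c4ccc(C(F)(F)F)cc4)c(C)nc23)C1`: > 95%

These values come from an ADME assay on microsomes from liver (Mus musculus) for metabolic stability, read by LC-MS, with NADPH named in the record, with a stated time of 60 min, tested at 1 uM, in the absence of a further agent; a higher number here means that more of the compound is left, a lower number that less of the compound is left. The picture so far is uniform: the limit of > 95% in this assay, at which 3 of the 3 values shown sit. Compound 3 stands at > 95%, which is a limit of the assay and not a number.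

Compound 4 `COc1ccc(-c2c(C)nc3c(N4CC[C@@H](NC(C)=O)C4)cc(C)nn23)cc1F` is still unmeasured. It carries 3-fluoro-4-methoxyphenyl in place of 4-(trifluoromethyl)phenyl, on an aromatic carbon of a five-membered aromatic ring: 3-fluoro-4-methoxyphenyl in place of 4-(trifluoromethyl)phenyl on an aromatic carbon. For the measured compounds named here, no measured step shows what such a swap does. Compound 1 also carries methoxy groups and gives > 95%, again a limit. Compound 2 also carries methoxy groups and gives > 95%, likewise a limit.

The expected change, a number at least 5 percentage points lower from compound 3 to compound 4 (that floor lies within the scatter), is slightly downward and stays within the usual scatter. For compound 4 the estimated value is 90%, with an expected range of 72% to 100%.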

Compound 4, percent of the compound remaining: > 95%
Compound 4 ended at the assay's limit; the forecaster's own chance of this, stated with the estimate: 50%; at least 5 percentage points between middle value and limit.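

For the compounds shown here, compound 3 and compound 4 both sit at a limit of this assay, so no step between them can be read. Whether 3-fluoro-4-methoxyphenyl in place of 4-(trifluoromethyl)phenyl changes how much compound remains stays open, as the compounds shown offer no number to settle it: the limit of > 95% in this assay, at which 4 of the 4 values shown sit.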